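A few compounds are considered here, and "the series" means these few. Any claim that something is new, unique, unknown or untested is made for them only; others in the source may bear on it.

The set comprises three measured compounds and one still to be measured, all sharing the same core. Compound 1 `COc1cc(/C=C2\CCC/C(=C\c3ccccc3[N+](=O)[O-])C2=O)cc(OC)c1OC` gives 4.86 in a physicochemical assay for lipophilicity; on this read-out lower numbers stand for lower lipophilicity and higher numbers for higher lipophilicity. Compound 3 `O=C1/C(=C/c2ccc(Cl)cc2)CCC/C1=C\c1ccccc1[N+](=O)[O-]` gives 4.86 in this assay. Compound 2 `O=C1/C(=C/c2ccc(F)cc2)CCC/C1=C\c1cccc([N+](=O)[O-])c1` gives 5.06 in this assay, which is the highest of the three numbers, though its nearest neighbour, compound 1, and its furthest, compound 3, both sit within the scatter of it, so no order among the three can be read from these values.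

Compound 4 `CN(C)c1ccc(/C=C2\CCC/C(=C\c3cccc([N+](=O)[O-])c3)C2=O)cc1` has not yet been measured in this assay. Its difference from compound 2 is a single one: dimethylamino in place of fluoro on an aromatic carbon. Among the compounds with values here, no pair of measured compounds differs in this one place, so no measured step speaks to the size of the change. The expectation therefore rests on the value of compound 2 alone, and the step from compound 2 to compound 4 is expected to be a number 0.04 log units higher from compound 2 to compound 4 (within the scatter), which is not beyond the scatter. On that basis compound 4 is estimated at 5.1 in this assay, with a range from 4.6 to 5.6.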

Compound 4, partition coefficient: 5.06
Beside the measured number, compound 4's estimate is 0.04 log units above it; the measured number falls inside the stated range.
By their numbers in this assay, from the lowest: compounds 1, 3, 2 and 4 (each within the scatter of the next).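

Within the data shown here, this pair gives the first reading of a single change at this position. The earlier compounds shown here could not supply one, as none of them differed from another in one place only. In this assay, dimethylamino in place of fluoro on an aromatic carbon, para to a large group, gives no change at the digits printed from compound 2 to compound 4 (within the scatter), even though the entering group has 3 heavy atoms against 1 for fluoro and brings 1 hydrogen-bond acceptor where fluoro counts none, so on this read-out and for this pair the larger substituent leaves the number where it was. Nothing available offers an account of why the read-out holds across this change.

A single pair cannot show whether other groups at this position, such as a carboxylic acid, a primary amine or a longer chain, would also stay within the scatter of compound 2. Also open, from the compounds shown here alone, is whether the same change would give the same step if the other aryl group of the shared core were that of compound 1 or compound 3, rather than that of compound 2.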